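Methylsulfonyl in place of methylsulfanyl on the compound 2 core

A few compounds are considered here, and "the series" means these few. Any claim that something is new, unique, unknown or untested is made for them only; others in the source may bear on it.

Compound 2 `CSc1ccc(C)cc1NCC1=NCCN1` gives 0.912 nM in a functional assay for agonist activity at Alpha-1D adrenergic receptor (Homo sapiens); a higher number here means that more compound is needed for the effect, a lower number that less compound is needed.
Compound 1 `COc1ccc(S(C)(=O)=O)c(NCC2=NCCN2)c1` gives only a limit in this assay, < 100000 nM.
Compound 3 `CS(=O)(=O)c1cccc(F)c1NCC1=NCCN1` gives only a limit in this assay, < 100000 nM.

Among the compounds with values here, compound 2 is the only compound with a numerical value in this assay; the other two entries are limits, namely (the limit of < 100000 nM in this assay, at which 2 of the 3 values shown sit). Compound 4 `Cc1ccc(S(C)(=O)=O)c(NCC2=NCCN2)c1` has not been measured. It differs from compound 2 by methylsulfonyl in place of methylsulfanyl on an aromatic carbon. Within the data shown here, no step between two measured compounds covers this change directly, so the size of the step rests on the other entries. Among the measured compounds shown here, compound 1 and compound 3 both carry the methylsulfonyl group that enters here, and both sit at the limit of < 100000 nM in this assay, at which 2 of the 3 values shown sit, whereas compound 2, with methylsulfanyl, is the single potent member. A large loss of potency is therefore expected from compound 2 to compound 4, estimated as a 5500-fold higher number from compound 2 to compound 4 (3.74 log units; beyond the scatter), well beyond the scatter. Compound 4 is expected to give about 5000 nM, within a range of 200 nM to 100000 nM, with a real chance that only a limit is reported.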

Compound 4, half-maximal effective concentration: < 2000 nM
Compound 4 ended at the assay's limit (the forecaster's own chance of this, stated with the estimate: 40%); middle value at least 2.5-fold (0.39 log units) away from the limit.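

In this assay compound 4 gives only a limit, < 2000 nM, so neither the step from compound 2 to compound 4 nor the step from compound 1 to compound 4 can be read. The compounds shown leave open how large the change from methylsulfanyl to methylsulfonyl is on the core of compound 2, and whether methyl in place of methoxy changes the number at all.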